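Swapping a Benzyl for a Saturated Ring in Compound 4

The source may hold more compounds than are shown below. What is called first, only, known or untested is meant among the compounds shown, and "the series" means these compounds.

Compound 1 `O=C1NC2=C(C(=O)OCC2)C(c2cccc(O)c2)N1` reaches only the assay limit of > 10000 nM in an ADME assay on cells (Homo sapiens) for cytotoxicity; a lower number here means that less compound is tolerated, a higher number that more compound is tolerated.
Compound 2 `CCC1=C(C(=O)CCC2CCCC2)[C@H](c2ccc(O)c(Cl)c2)NC(=O)N1` likewise reaches only the limit of > 10000 nM in this assay.
Compound 3 `CCC1=C(C(=O)CCc2ccccc2)[C@H](c2ccc(O)c(Cl)c2)NC(=O)N1` again stops at the limit of > 10000 nM in this assay.

None of the three measured compounds gives an actual number: each sits at the same ceiling, as summed up by the limit of > 10000 nM in this assay, at which 3 of the 3 values shown sit. Compound 3 therefore stands exactly where the other two stand, and no ordering among them can be read. For the measured compounds named here, the one measured change that differs in a single place, a step that the two limits leave unreadable from compound 2 to compound 3, is a swap of phenyl for cyclopentyl on a saturated chain carbon two bonds along from a carbonyl carbon, and since both ends rest at the limit its size stays hidden.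

Compound 4 `CCC1=C(C(=O)CC2CCC(C)CC2)[C@H](c2ccc(O)c(Cl)c2)NC(=O)N1` differs from compound 3 by 4-methylcyclohexyl in place of benzyl on a saturated chain carbon bound to a carbonyl carbon. Going by the values given here, this is again an exchange of an aromatic ring for a saturated one on the same chain, so the only step that bears on it is the unreadable one from compound 2 to compound 3, which offers no direction and no size. Compound 4 is therefore expected to stay at the ceiling as well, a step that the limit leaves unreadable from compound 3 to compound 4. The estimate for compound 4 is 15000 nM, within 5000 nM to 50000 nM.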

Compound 4, half-maximal cytotoxic concentration: > 10000 nM
Compound 4 ended at the assay's limit (the forecaster's own chance of this, stated with the estimate: 85%); the middle value lies beyond the limit too.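

Compound 4 also gives only a limit, so the steps to it from compound 2 and compound 3 cannot be read, and the four compounds cannot be ranked: the limit of > 10000 nM in this assay, at which 4 of the 4 values shown sit. Left open is what actual number in this assay any of these compounds would give, and so whether exchanging phenyl, cyclopentyl or 4-methylcyclohexyl makes any difference at all.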